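The source may report more compounds than this note shows. Statements on the series, on what has been measured and on what is new or still open speak of the compounds shown alone.

Measured compounds in a functional assay on cells (leukaemia cell line, Homo sapiens) for inhibition, read by sulforhodamine B assay, with a stated time of 48 h; on this read-out higher numbers stand for weaker inhibition of growth and lower numbers for stronger inhibition of growth:
- compound 1 `O=S(=O)(Nc1ccc(Cl)c(Cl)c1)c1ccc(-c2cnc(C3CC3)o2)cc1`: compound 1 gives 62100 nM.
- compound 2 `O=S(=O)(Nc1ccccc1Cl)c1ccc(-c2cnc(C3CC3)o2)cc1`: compound 2 gives 49700 nM.
- compound 3 `Cc1ccc(NS(=O)(=O)c2ccc(-c3cnc(C4CC4)o3)cc2)cc1C`: compound 3 reaches only the assay limit, > 100000 nM.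

Compound 1 holds the highest of the two numbers; compound 2 sits within the scatter of it, a 1.2-fold lower number from compound 1 to compound 2 (0.10 log units; within the scatter). Compound 3 sits at the limit (the limit of > 100000 nM in this assay, at which 1 of the 3 values shown sits), so an at least 1.6-fold higher number from compound 1 to compound 3 (0.20 log units; that floor lies within the scatter) has a floor that also lies within the scatter.

Compound 4 `O=S(=O)(Nc1ccc(F)cc1F)c1ccc(-c2cnc(C3CC3)o2)cc1` differs from compound 1 as follows: 2,4-difluorophenyl in place of 3,4-dichlorophenyl on a sulfonamide nitrogen. The step that bears most on it is the swap of halogenated phenyl groups on the sulfonamide nitrogen, a 1.2-fold lower number from compound 1 to compound 2 (0.10 log units; within the scatter), which stayed within the scatter. A step of similar small size, a 1.0-fold lower number from compound 1 to compound 4 (0.01 log units; within the scatter), is therefore expected in this assay, in no clear direction. Compound 4 is estimated at 60000 nM, with a range of 25000 nM to 150000 nM.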

Compound 4, concentration for total growth inhibition: 66100 nM
The estimate for compound 4 lay 1.1-fold (0.04 log units) below the measured number; the measured number falls inside the stated range.
By their numbers in this assay, from the lowest: compounds 2, 1 and 4 (each within the scatter of the next). At a limit, above all of these: compound 3.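

In this assay, a third halogenated phenyl group on a sulfonamide nitrogen stays within the scatter of both earlier ones: a 1.1-fold higher number from compound 1 to compound 4 (0.03 log units; within the scatter), and a 1.3-fold higher number from compound 2 to compound 4 (0.12 log units; within the scatter). Fluorine on the ring, so far seen only as 2,4-difluorophenyl, therefore gives no step beyond the scatter from the chlorinated compounds. Compound 3 stands at a limit. Only a floor is known for the step from it (an at least 1.5-fold lower number from compound 3 to compound 4 (0.17 log units; that floor lies within the scatter)), and the true size of that step cannot be read: the limit of > 100000 nM in this assay, at which 1 of the 4 values shown sits.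

No group shown on this nitrogen gives a step beyond the scatter. From the compounds shown here alone, whether a phenyl group carrying a carboxylic acid or an amine, or a longer chain in place of the phenyl group, would do so remains open.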